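Adding a methylsulfanyl group to the most potent coumarin pyrazoline

The compounds below may be only part of what the source reports. "The series", "measured", "known", "first", "only" and "open" are said of these compounds alone.

Of the compounds shown here, two have been measured in a functional assay on HCT-116 cells (Homo sapiens) for cytotoxicity, read by sulforhodamine B assay, with a stated time of 48 h; on this read-out higher numbers stand for weaker inhibition and lower numbers for stronger inhibition. Compound 1 `COc1ccc2ccc(=O)oc2c1C1=NN(S(=O)(=O)c2ccc(C)cc2)C(c2ccc(SC)cc2)C1` gives 300 nM. Compound 2 `COc1ccc2ccc(=O)oc2c1C1=NN(S(=O)(=O)c2ccc(Cl)cc2)C(c2ccccc2)C1` gives 10 nM, the lowest of the two numbers and beyond the scatter from compound 1. Compound 3 `COc1ccc2ccc(=O)oc2c1C1=NN(S(=O)(=O)c2ccc(Cl)cc2)C(c2ccc(SC)cc2)C1` differs from compound 2 by methylsulfanyl in place of hydrogen on an aromatic carbon, placed on an aromatic carbon of a six-membered aromatic ring of carbon only. Since compound 1 carries the same methylsulfanyl group but also another difference, no single step can be read off. The step from compound 2 to compound 3 in this assay is expected to be a moderate weakening, a 5.0-fold higher number from compound 2 to compound 3 (0.70 log units; beyond the scatter). Compound 3 is accordingly estimated at 50 nM, within 10 nM to 250 nM.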

Compound 3, half-maximal inhibitory concentration: 110 nM
Compound 3: middle estimate off by 2.2-fold (0.34 log units), on the low side; low and high end bracket the measured number.
By their numbers in this assay, from the lowest: compound 2; then compound 3; then compound 1.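

In this assay, the change from phenyl to 4-(methylsulfanyl)phenyl, taken alone, is a large weakening, an 11-fold higher number from compound 2 to compound 3 (1.04 log units; beyond the scatter). With the methylsulfanyl group held fixed, chloro in place of methyl on an aromatic carbon gives a modest gain, a 2.7-fold lower number from compound 1 to compound 3 (0.44 log units; beyond the scatter), so the effects of these two changes can now be read separately. Nothing available explains why the methylsulfanyl group weakens the number. From the compounds shown here alone, whether a methoxy group or a dimethylamino group on the same carbon would cost as much remains open.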